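The source may report more compounds than this note shows. Statements on the series, on what has been measured and on what is new or still open speak of the compounds shown alone.

For the measured compounds named here, in a functional assay on DU-145 cells (Homo sapiens) for inhibition, read by trypan blue exclusion, with a stated time of 96 h (a higher number here means a weaker inhibitor of growth, a lower number a stronger inhibitor of growth), compound 2 `O=C(/C(=C\c1ccc(F)cc1F)Sc1ccc(Br)cc1)c1ccc(Cl)cc1` gives 1000 nM, the only true number available so far. Compound 1 `CN(C)c1ccc(/C=C(/Sc2ccc(Br)cc2)C(=O)c2ccc(Cl)cc2)cc1` reads > 100000 nM, which is a limit of the assay and not a number.

The next compound to consider is compound 3 `COc1ccccc1/C=C(/Sc1ccc(Br)cc1)C(=O)c1ccc(Cl)cc1`, which has not yet been measured. It keeps the core of compound 2 and changes one group: 2-methoxyphenyl in place of 2,4-difluorophenyl on a double-bonded chain carbon bound to a double-bonded chain carbon. The change is 2-methoxyphenyl in place of 2,4-difluorophenyl on a double-bonded chain carbon bound to a double-bonded chain carbon.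

Going by the values given here, only one measured step concerns this place: an at least 100-fold lower number from compound 1 to compound 2 (2.00 log units; beyond the scatter). This large step lies beyond the scatter, so the group here can matter a great deal in this assay. However, it is a single step, and no measured compound yet carries 2-methoxyphenyl. With compound 2 at 1000 nM, the better of the two results, a replacement seems more likely to weaken growth inhibition than to improve it.

The expected change is a 3.0-fold higher number from compound 2 to compound 3 (0.48 log units; beyond the scatter), a moderate rise in the number. For compound 3 the estimated value is 3000 nM, with an expected range from 500 nM to 20000 nM.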

Compound 3, concentration for 50% growth inhibition: 10000 nM
For compound 3 the middle estimate is 3.3-fold (0.52 log units) below the measured one; the range from low to high includes it.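

Among the three groups tried at this double-bonded chain carbon, the order in this assay is now graded rather than all-or-nothing. Replacing 2,4-difluorophenyl with 2-methoxyphenyl, which has the same heavy-atom count, gives a 10-fold higher number from compound 2 to compound 3 (1.00 log units; beyond the scatter), so this position responds even to a swap that leaves the group's size in heavy atoms unchanged, while replacing 4-(dimethylamino)phenyl with 2-methoxyphenyl gives an at least 10-fold lower number from compound 1 to compound 3 (1.00 log units; beyond the scatter), which places compound 3 between the other two compounds. Compound 1 supplies a limit and not a number, so this last step has only a lower bound on its size: the limit of > 100000 nM in this assay, at which 1 of the 3 values shown sits.

The three groups differ in more than one feature at once, so the compounds shown cannot say whether the fluorines of compound 2 help growth inhibition, or whether the methoxy of compound 3 or the dimethylamino group of compound 1 harms it. A plain phenyl ring at this carbon would give the missing reference point, and a group carrying a carboxylic acid would test a very different kind of substituent here.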